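Methoxy for Chloro on a Second Core

The source may hold more compounds than are shown below. What is called first, only, known or untested is meant among the compounds shown, and "the series" means these compounds.

Measured so far:
compound 1, `Cc1cc(C)c2c(O)cc(-c3ccc(Cl)cc3)nc2n1`, 16200 nM
compound 2, `COc1ccc(-c2cc(O)c3c(C)cc(C)nc3n2)cc1`, 42700 nM
compound 3, `Cc1cnc2nc(-c3ccc(Cl)cc3)cc(O)c2c1`, 2400 nM

The three measured compounds were tested in a functional assay on SF-295 cells (Homo sapiens); a lower number here means a stronger inhibitor of growth, a higher number a weaker inhibitor of growth. Compound 1 and compound 2 share one core and differ in a single place: methoxy in place of chloro on an aromatic carbon. That change gave a 2.6-fold higher number from compound 1 to compound 2 (0.42 log units; beyond the scatter). Compound 3 carries a different core; the difference between the two cores is not broken down here. What the values show is that compound 3 gives the lowest number of the three, with compound 1 nearest to it and compound 2 furthest away.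

The compound not yet measured, compound 4, `COc1ccc(-c2cc(O)c3cc(C)cnc3n2)cc1`, stands to compound 3 as compound 2 stands to compound 1: methoxy in place of chloro on an aromatic carbon. The two changes have the same place described in the same words, so this is the same change made on a second core. Among the compounds shown, it has been measured once.

For the measured compounds named here, with only that one earlier step to go on, the expectation is that the change on the core of compound 3 will move the number in the same direction and by about the same amount. Compound 4 is therefore estimated to show a 2.6-fold higher number from compound 3 to compound 4 (0.41 log units; beyond the scatter) in this assay, the expected size resting on the earlier step from compound 1 to compound 2. The estimate for compound 4 is 6200 nM, with a range from 2800 nM to 14000 nM; the range is wide because the change has been seen only once and on a different core.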

Compound 4, concentration for 50% growth inhibition: 5250 nM
The estimate for compound 4 lay 1.2-fold (0.07 log units) above the measured number, within the range that was stated.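

In this assay the swap of chloro for methoxy, on an aromatic carbon para to a large group, gave a 2.2-fold higher number from compound 3 to compound 4 (0.34 log units; beyond the scatter) on the second core. Set beside the first case, the change carried over from one core to the other with the same direction and a matching size: the same change on two cores in this assay, a 2.6-fold higher number (0.42 log units; beyond the scatter) from compound 1 to compound 2 and a 2.2-fold higher number (0.34 log units; beyond the scatter) from compound 3 to compound 4, 1.2-fold (0.08 log units) apart, within the scatter of two such steps. This supports treating the swap as transferable between these two cores in this one cell assay, but it rests on just two pairs of compounds, so it does not show that a third core would respond in the same way, and it does not explain why the number rises with methoxy in either case.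

The compounds shown leave open how other groups on that aromatic carbon would behave, for example fluoro, trifluoromethyl, an amine, a carboxylic acid, or a longer chain such as ethoxy or propoxy, as only chloro and methoxy appear there. They also leave open how the difference between the two cores itself bears on the number, since no pair shown here isolates a single change in the core.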